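From 2-fluorophenyl to 3,4-dimethylphenyl, behind assay limits

The source may report more compounds than this note shows. Statements on the series, on what has been measured and on what is new or still open speak of the compounds shown alone.

Measured in a functional assay on KB cells (Homo sapiens) for antiproliferative activity, read by sulforhodamine B assay, with a stated time of 3 days; a higher number here means that more compound is needed for the effect, a lower number that less compound is needed:
Compound 1 `CCOc1ccc(-c2cc(=O)c3c(o2)C(CC)(CC)C(=O)C(CC)=C3O)cc1`: > 52.4 uM
Compound 2 `CCC1=C(O)c2c(oc(-c3ccc(Br)cc3)cc2=O)C(CC)(CC)C1=O`: > 48.1 uM
Compound 3 `CCC1=C(O)c2c(oc(-c3ccccc3F)cc2=O)C(CC)(CC)C1=O`: > 56.2 uM

All three entries are limits and not numbers. Compound 3 stands at > 56.2 uM, which is a limit. Compound 4 `CCC1=C(O)c2c(oc(-c3ccc(C)c(C)c3)cc2=O)C(CC)(CC)C1=O` differs from it by 3,4-dimethylphenyl in place of 2-fluorophenyl on an aromatic carbon. Two measured steps change this same group: a step that the two limits leave unreadable from compound 1 to compound 3 and a step that the two limits leave unreadable from compound 2 to compound 3. Neither has a readable size, so neither gives a direction, and no step beyond the scatter is expected in this assay. The expected step is an at least 1.0-fold lower number from compound 3 to compound 4 (0.00 log units; that floor lies within the scatter). Compound 4 is expected to give another limit. For compound 4 the estimate is 55 uM, with an expected range from 30 uM to 60 uM.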

Compound 4, concentration for half-maximal effect: 35.5 uM
For compound 4 the middle estimate is 1.5-fold (0.19 log units) above the measured one; low and high end bracket the measured number.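

Steps among compound 1, compound 2 and compound 3 cannot be read, and in this assay compound 4, with 3,4-dimethylphenyl on the carbon next to the ring oxygen, is the only one to give a number and not a limit. That number gives an at least 1.5-fold lower number from compound 3 to compound 4 (0.19 log units; that floor lies within the scatter), an at least 1.3-fold lower number from compound 2 to compound 4 (0.13 log units; that floor lies within the scatter) and an at least 1.4-fold lower number from compound 1 to compound 4 (0.16 log units; that floor lies within the scatter). The first of these steps stays a floor because the value of compound 3 is a limit: the limit of > 56.2 uM in this assay, at which 1 of the 4 values shown sits.

As far as these compounds go, it remains open what a single methyl group at this phenyl ring would give, and whether the size of these steps lies beyond the scatter. Also open, from the compounds shown here alone, is how an amine or a carboxylic acid on that ring would read.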